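This account rests on a few compounds, and the source may have more. Where it says the series, first, only, none or still open, it means among the compounds named here.

Compound 1 `CCc1ccc(C(=O)NC(=O)c2ccccc2O)cc1`: 70 ug/mL
Compound 2 `Cc1ccc(C(=O)NC(=O)c2ccccc2O)cc1`: 46 ug/mL
Compound 3 `CC(C)c1ccc(C(=O)NC(=O)c2ccccc2O)cc1`: 19 ug/mL

These three compounds were tested in an ADME assay on L6 cells (Rattus norvegicus) for cytotoxicity, read by resazurin assay, with a stated time of 72 h; on this read-out higher numbers stand for weaker inhibition and lower numbers for stronger inhibition. Among them, compound 3 gives 19 ug/mL, the lowest number of the three and the strongest inhibition seen so far. The next compound, compound 4 `N#Cc1ccc(C(=O)NC(=O)c2ccccc2O)cc1`, carries cyano in place of isopropyl on an aromatic carbon.

Among the compounds with values here, two measured steps bear on this change, as both arrive at the isopropyl group: a 2.4-fold lower number from compound 2 to compound 3 (0.38 log units; beyond the scatter), and a 3.7-fold lower number from compound 1 to compound 3 (0.57 log units; beyond the scatter). By contrast, the remaining step stays small: a 1.5-fold lower number from compound 1 to compound 2 (0.18 log units; within the scatter). Within the data shown here, compound 3 is the only measured compound with isopropyl, and compound 4 gives that group up. A modest move back towards a higher number is therefore expected. Among the measured compounds shown here, no measured step involves cyano, which leaves the size of this move uncertain, and the range must stay wide.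

The estimated step is a 2.1-fold higher number from compound 3 to compound 4 (0.32 log units; beyond the scatter). For compound 4, the expected value is 40 ug/mL, with an estimated range from 15 ug/mL to 90 ug/mL.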

Compound 4, half-maximal inhibitory concentration: 55 ug/mL
The estimate for compound 4 lay 1.4-fold (0.14 log units) below the measured number, within the range that was stated.
By their numbers in this assay, from the lowest: compound 3; then compounds 2, 4 and 1 (each within the scatter of the next).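

Swapping isopropyl for cyano at this position in this assay gives up the lowest number of the series (a 2.9-fold higher number from compound 3 to compound 4 (0.46 log units; beyond the scatter)), while the steps from the other two compounds stay within the scatter (a 1.2-fold higher number from compound 2 to compound 4 (0.08 log units; within the scatter); a 1.3-fold lower number from compound 1 to compound 4 (0.10 log units; within the scatter)). Cyano, which brings a triple bond and a hydrogen-bond acceptor, therefore reads level with methyl and ethyl, and among these four compounds only isopropyl stands apart. No measurement here explains why these very different groups read alike or why isopropyl differs.

Still open, from the compounds shown here alone, is whether the lower number with isopropyl follows from its branched shape, which another branched group such as tert-butyl or cyclopropyl could test. Going by these compounds, how a halogen such as chlorine, or an amine, would read at this position also remains unknown.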